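Lengthening the amide substituent of a cyclopropane carboxamide

This account rests on a few compounds, and the source may have more. Where it says the series, first, only, none or still open, it means among the compounds named here.

Measured compounds:
compound 1 `CC1(C)C(C(N)=O)C1(C)C` gives 52 mg/kg in a functional assay on the whole organism with Rattus norvegicus as the target; on this read-out higher numbers stand for an effect only at larger amounts of compound and lower numbers for an effect already at smaller amounts
compound 2 `CNC(=O)C1C(C)(C)C1(C)C` gives 45 mg/kg in this assay

Compound 2 has the lower of the two numbers in this assay, yet its nearest neighbour is compound 1, and the step of a 1.2-fold lower number from compound 1 to compound 2 (0.06 log units; within the scatter) lies within the scatter, so the two cannot be told apart on this read-out. For the measured compounds named here, that single step, a methyl in place of hydrogen on the amide-type nitrogen, is the only measured change bearing on what comes next.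

Compound 3 `CC1(C)C(C(=O)NCC(N)=O)C1(C)C` has not yet been measured. It differs from compound 2 by carbamoyl in place of hydrogen on a saturated chain carbon bound to an amide-type nitrogen; the group leaving is a hydrogen atom with no heavy atom, the group entering is a carbamoyl with one hydrogen-bond donor and one hydrogen-bond acceptor and no net charge. The earlier change on the same nitrogen, a 1.2-fold lower number from compound 1 to compound 2 (0.06 log units; within the scatter), altered the number only within the scatter. The step of no change at the digits printed from compound 2 to compound 3 (within the scatter) is therefore expected to stay within the scatter as well. Compound 3 is estimated at 45 mg/kg, with a range from 20 mg/kg to 100 mg/kg.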

Compound 3, dose for half-maximal effect: > 250 mg/kg
Compound 3 gave a limit, no number (the forecaster's own chance of this, stated with the estimate: 10%); middle value at least 5.5-fold (0.74 log units) from the limit.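

In this assay compound 3 gives > 250 mg/kg, which is a limit and not a number. The amide nitrogen turns out not to be indifferent to what it carries: the methyl of compound 2 stayed within the scatter of compound 1, whereas carbamoylmethyl in place of hydrogen on that nitrogen brings an at least 4.8-fold higher number from compound 1 to compound 3 (0.68 log units; beyond the scatter), and carbamoyl in place of hydrogen on the saturated chain carbon brings an at least 5.5-fold higher number from compound 2 to compound 3 (0.74 log units; beyond the scatter). A position that looked insensitive with methyl is therefore sensitive to this larger substituent, in the direction of an effect only at larger amounts of compound, while the full size of the change stays undetermined, as the result is a limit: the limit of > 250 mg/kg in this assay, at which 1 of the 3 values shown sits.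

The three compounds cannot separate the contribution of the terminal carbamoyl from that of the extra chain carbon, as methyl and carbamoylmethyl differ in both respects. An ethyl group, a longer plain carbon chain, or a chain ending in a hydroxyl group, an amine or a carboxylic acid would each be a further single change at this nitrogen, and the behaviour of any of them cannot be told from these results.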